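Adding 2-carboxyethyl to compound 2

A few compounds are considered here, and "the series" means these few. Any claim that something is new, unique, unknown or untested is made for them only; others in the source may bear on it.

In an ADME assay on MRC5 cells (Homo sapiens) for cytotoxicity, read by fluorescence and resazurin assay, with a stated time of 3 days (on this read-out lower numbers stand for an effect already at smaller amounts and higher numbers for an effect only at larger amounts of compound), compound 1 (`O=C1C=CC(O)(c2ccccc2)C=C1`) gives 1700 nM as its half-maximal effective concentration. Compound 2 (`O=C1C=CC(O)(c2cc3ccccc3n2S(=O)(=O)c2ccccc2)C=C1`) gives 110 nM there, the lower of the two numbers and set apart from compound 1 by more than the usual scatter. Compound 3 (`O=C1C=CC(O)(c2cc3ccccc3n2S(=O)(=O)c2ccc(CCC(=O)O)cc2)C=C1`) has not yet been measured. It differs from compound 2 by a 2-carboxyethyl in place of hydrogen on an aromatic carbon, para to a large group (2-carboxyethyl in place of hydrogen on an aromatic carbon). Among the compounds with values here, no measured pair shows a change of this kind, so the expectation rests on thin ground. With compound 2 at 110 nM as the lower number, a higher number for compound 3 seems the likelier outcome. In this assay the expected change is a rise beyond the scatter (a 4.1-fold higher number from compound 2 to compound 3 (0.61 log units; beyond the scatter)). Compound 3 is estimated at 450 nM (expected range 130 nM to 1600 nM).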

Compound 3, half-maximal effective concentration: 3300 nM
The estimate for compound 3 lay 7.3-fold (0.87 log units) below the measured number, and the stated range ends below it.
By their numbers in this assay, from the lowest: compound 2; then compounds 1 and 3 (each within the scatter of the next).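

In this assay, 2-carboxyethyl in place of hydrogen on an aromatic carbon, para to a large group, gives a 30-fold higher number from compound 2 to compound 3 (1.48 log units; beyond the scatter), the first step measured at this position and a large one. This position of compound 2 is therefore not a silent one: a single added group here moves the number upward, well beyond the scatter. Nothing available explains the size of this step.

The compounds shown leave open whether the rise follows from the carboxylic acid at the end of the chain or from the chain itself, which a methyl ester, an amide or an amine on the same chain could separate. They also leave open how a shorter or longer chain ending in a carboxylic acid would read at this position.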